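A few compounds are considered here, and "the series" means these few. Any claim that something is new, unique, unknown or untested is made for them only; others in the source may bear on it.

Compound 1 `CC(C)(C)C(=O)Oc1ccccc1/C=C1\CCCN=C1c1cccnc1` — 1440 nM
Compound 2 `C(=C1\CCCN=C1c1cccnc1)\c1ccc2c(c1)OCCO2` — 520 nM

Both compounds were tested in an assay on membranes from brain for displacement of a labelled ligand from Neuronal acetylcholine receptor; alpha4/beta2 (Rattus norvegicus), with a stated time of 3 h; on this read-out higher numbers stand for weaker inhibition and lower numbers for stronger inhibition. Compound 1 gives 1440 nM, and compound 2 gives 520 nM. Compound 1 thus stands at the higher of the two numbers, and its gap to compound 2 lies beyond the usual scatter. The two structures differ in more than one place, so no single step can be read from that pair.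

Compound 3 `CC(=O)Oc1ccccc1/C=C1\CCCN=C1c1cccnc1` has not yet been measured. It differs from compound 1 by methyl in place of tert-butyl on a carbonyl carbon. Within the data shown here, no measured pair shows this exchange, so its effect in this assay is unknown from the data at hand. The change is confined to the group on the carbonyl carbon of the ester, and the shared core is untouched. On that basis the author expects only a modest step, a 1.3-fold lower number from compound 1 to compound 3 (0.12 log units; within the scatter), within or close to the scatter and with a slight lean towards a lower number. Compound 3 is therefore estimated at 1100 nM in this assay, with a range from 400 nM to 3200 nM.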

Compound 3, inhibition constant: 700 nM
Compound 3: middle estimate off by 1.6-fold (0.20 log units), on the high side, within the range that was stated.
By their numbers in this assay, from the lowest: compounds 2 and 3 (each within the scatter of the next); then compound 1.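

The group on the carbonyl carbon of the ester turns out to matter on its own: in this assay, methyl in place of tert-butyl gives a 2.1-fold lower number from compound 1 to compound 3 (0.31 log units; beyond the scatter). Among these compounds, this is the first comparison in the set that changes one place only, so it isolates an effect that the pair of compounds 1 and 2, which differ in more than one place, could not reveal, and it shows that this position responds to a change with the shared core left untouched. The step is modest but lies beyond the usual scatter, pointing towards stronger inhibition, although nothing available explains why the number moves in this direction.

With only two groups compared at this position, the compounds shown leave open whether the number would change steadily or irregularly with ethyl or isopropyl on the same carbonyl carbon, so no trend can yet be drawn from tert-butyl and methyl alone. They also leave open whether the ester itself is needed, since a free hydroxyl or an acetamide in place of the acetoxy group would test what this part of the molecule contributes in this assay.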